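4-Fluorophenyl to 3-fluorophenyl on the shared core

The source may report more compounds than this note shows. Statements on the series, on what has been measured and on what is new or still open speak of the compounds shown alone.

In a functional assay on HCT-116 cells (Homo sapiens) for inhibition, read by MTT assay, with a stated time of 72 h (on this read-out higher numbers stand for weaker inhibition and lower numbers for stronger inhibition), compound 1 `Cc1nc(-c2ccc(F)cc2)c(C(=O)N2CCN(c3cc(Cl)cc(Cl)c3)CC2)o1` gives 484 nM and compound 2 `COc1cc(OC)cc(N2CCN(C(=O)c3oc(C)nc3-c3ccc(F)cc3)CC2)c1` gives 404 nM as its value. Compound 2 therefore stands level with compound 1, within the scatter. Within the data shown here, compound 3 `COc1cc(OC)cc(N2CCN(C(=O)c3oc(C)nc3-c3cccc(F)c3)CC2)c1` carries 3-fluorophenyl in place of 4-fluorophenyl on an aromatic carbon as its sole change. Among the measured compounds shown here, the one measured step (a 1.2-fold lower number from compound 1 to compound 2 (0.08 log units; within the scatter)) concerns another place, so it offers only indirect guidance. No shift beyond the scatter is expected in this assay in either direction. The expected step is small (a 1.0-fold higher number from compound 2 to compound 3 (0.02 log units; within the scatter)). Compound 3 is estimated at 420 nM as a value (range 170 nM to 1000 nM).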

Compound 3, half-maximal inhibitory concentration: 216 nM
Beside the measured number, compound 3's estimate is 1.9-fold (0.29 log units) above it, and the stated range covers the measured number.
By their numbers in this assay, from the lowest: compounds 3, 2 and 1 (each within the scatter of the next, the first and the last beyond it).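

In this assay the change to 3-fluorophenyl from 4-fluorophenyl, on the aromatic carbon next to the ring nitrogen, gives a 1.9-fold lower number from compound 2 to compound 3 (0.27 log units; within the scatter) as the first step read at this position. The fluorine can therefore occupy either printed position on this phenyl without a shift beyond the scatter. Nothing available explains this result.

From the compounds shown here alone, both groups at this position are fluorophenyl rings, so the range of groups tolerated here remains open. Going by these compounds, whether a pyridine ring or a phenyl bearing a carboxylic acid would hold the number in this range also remains unknown.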